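Moving a methoxy group on the cinnamide aryl ring

The source may report more compounds than this note shows. Statements on the series, on what has been measured and on what is new or still open speak of the compounds shown alone.

In a functional assay on MCF7 cells (Homo sapiens) for cytotoxicity, read by MTT assay, with a stated time of 72 h (on this read-out lower numbers stand for stronger inhibition and higher numbers for weaker inhibition), three compounds have been measured:
- compound 1 `COc1ccc(OC)c(/C=C/C(=O)Nc2cc3c(Nc4ccc(F)c(Cl)c4)ncnc3cc2OC)c1` gives 34300 nM
- compound 2 `COc1ccc(/C=C/C(=O)Nc2cc3c(Nc4ccc(F)c(Cl)c4)ncnc3cc2O[C@H]2CCOC2)c(OC)c1` gives 28600 nM
- compound 3 `O=C(/C=C/c1cc(Br)c(O)c(Br)c1)Nc1cc2c(Nc3ccc(F)c(Cl)c3)ncnc2cc1O[C@H]1CCOC1` gives 30600 nM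

Compound 1 at 34300 nM lies within the scatter of both other compounds, so these three values give no ranking. Compound 4 `COc1cc(/C=C/C(=O)Nc2cc3c(Nc4ccc(F)c(Cl)c4)ncnc3cc2OC)cc(OC)c1` keeps the core of compound 1 and carries 3,5-dimethoxyphenyl in place of 2,5-dimethoxyphenyl on a double-bonded chain carbon bound to a double-bonded chain carbon with nothing else altered.

Among the measured compounds shown here, only one measured step changes that aromatic group alone, and it shows a 1.1-fold higher number from compound 2 to compound 3 (0.03 log units; within the scatter) when 3,5-dibromo-4-hydroxyphenyl replaces 2,4-dimethoxyphenyl at the same place. For the measured compounds named here, that exchange alters the ring more than the one leading to compound 4, yet it stayed within the scatter. Compound 2 also carries a different dimethoxyphenyl group from compound 1, though its core differs too, and the values of these two lie within the scatter of each other. No step beyond the scatter is therefore expected in this assay and the estimated change is a 1.1-fold lower number from compound 1 to compound 4 (0.04 log units; within the scatter) in size. The expected value of compound 4 is 31000 nM with an estimated range from 15000 nM to 62000 nM in this read-out.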

Compound 4, half-maximal inhibitory concentration: 38500 nM
Beside the measured number, compound 4's estimate is 1.2-fold (0.09 log units) below it; the range from low to high includes it.
By their numbers in this assay, from the lowest: compounds 2, 3, 1 and 4 (each within the scatter of the next).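

Moving one methoxy group, so that 3,5-dimethoxyphenyl stands in place of 2,5-dimethoxyphenyl on the core of compound 1, gives in this assay a 1.1-fold higher number from compound 1 to compound 4 (0.05 log units; within the scatter). Unlike the earlier step, which exchanged the substituents themselves, this one keeps the same atoms and changes only how they are joined, and it shows that this rearrangement of the two methoxy groups does not separate the two compounds in this read-out. Nothing available bears on why the two values stay together.

From the compounds shown here alone, all the values shown lie close together, so it remains open whether any group at this place can shift the number beyond the scatter, for example an aryl ring carrying a dimethylamino group or a carboxylic acid, or a longer chain in place of the double-bonded one. Going by these compounds, it also remains open whether 3,5-dimethoxyphenyl would read the same on the core of compound 2, where the methoxy group of compound 1 is replaced by a different ether.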